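The source may report more compounds than this note shows. Statements on the series, on what has been measured and on what is new or still open speak of the compounds shown alone.

Compound 2 `CCOC(=O)c1oc2ccccc2c1C` stands highest of the three values in a physicochemical assay for solubility, read by nephelometry, in phosphate buffer, measured as kinetic solubility, at pH 7.4; on this read-out higher numbers stand for higher solubility and lower numbers for lower solubility: compound 2 gives 200000 nM, while compound 3 `Cc1ccc2oc(-c3c4c(N)n[nH]c(=O)c4nn3-c3ccc(NC(=O)/C=C/CN(C)C)cc3)c(C)c2c1` gives 50000 nM and compound 1 `C=CC(=O)Nc1ccc(-n2nc3c(=O)[nH]nc(N)c3c2-c2oc3ccc(C)cc3c2C)cc1` gives 20000 nM. Among the measured compounds shown here, the single measured step, a 2.5-fold higher number from compound 1 to compound 3 (0.40 log units; beyond the scatter), concerns a different change on the larger core and does not bear on the change at hand. Compound 4 `CCOC(=O)c1oc2ccc(Cl)cc2c1C` differs from compound 2 by chloro in place of hydrogen on an aromatic carbon. For the measured compounds named here, no measured pair of compounds shows a chloro in place of hydrogen, so the expectation rests on the change itself rather than on a measured step. The step is expected to be a modest fall, just beyond the scatter: a 2.0-fold lower number from compound 2 to compound 4 (0.30 log units; within the scatter). Compound 4 is estimated at 100000 nM, with a range from 30000 nM to 250000 nM.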

Compound 4, solubility: 200000 nM
Beside the measured number, compound 4's estimate is 2.0-fold (0.30 log units) below it, and the stated range covers the measured number.
By their numbers in this assay, from the lowest: compound 1; then compound 3; then compounds 2 and 4 (each within the scatter of the next).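

Among the compounds shown here, the step of no change at the digits printed from compound 2 to compound 4 (within the scatter) in this assay gives the first reading of chloro in place of hydrogen on an aromatic carbon, here meta to a fused ring and para to a fused ring. At this position the change stays within the scatter, though this rests on a single pair. Nothing available explains this result.

On these data alone, whether an amine or a carboxylic acid on this aromatic carbon would give a step beyond the scatter remains open. So does whether chloro would give the same result on the core of compound 1.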